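This account rests on a few compounds, and the source may have more. Where it says the series, first, only, none or still open, it means among the compounds named here.

Working notes on the series. Compound 1 `CCc1cccc2c(OC)c(-c3occ(C)c3C(=O)NC)ccc12` is the reference point for this step. In a functional assay on KBVIN cells (Homo sapiens) for cytotoxicity, read by MTT assay, with a stated time of 72 h (on this read-out lower numbers stand for an effect already at smaller amounts and higher numbers for an effect only at larger amounts of compound), compound 1 gives only a limit, > 10 ug/mL, not a number. Compound 2 `CCc1cccc2c(OC)c(-c3occ(C)c3C(=O)On3nnc4ccccc43)ccc12` carries a larger group on the carbonyl carbon in place of the methylamino group. In this assay compound 2 likewise gives only a limit, > 10 ug/mL. The step from compound 1 to compound 2 is therefore a step that the two limits leave unreadable from compound 1 to compound 2. Going by the values given here, compound 3 `CCOc1c(-c2occ(C)c2C(=O)OC)ccc2c(CC)cccc12` differs from compound 1 in more than one place, so no single step is drawn; in this assay compound 3 gives 1.7 ug/mL, a number rather than a limit.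

Compound 4 `CCc1cccc2c(OC)c(-c3occ(C)c3COCC(F)(F)F)ccc12` is the next target. Relative to compound 1 the change is (2,2,2-trifluoroethoxy)methyl in place of methylcarbamoyl on an aromatic carbon. Among the compounds with values here, no measured step reports a single change of this kind; the only step drawn from compound 1 is unreadable, and the limit of > 10 ug/mL in this assay, at which 2 of the 3 values shown sit, describes where compound 1 and compound 2 both sit. Compound 1 offers only a limit to start from, so the direction of the step from compound 1 to compound 4 cannot be read from the measured steps. Compound 4 is expected to give 12 ug/mL, within a range of 4 ug/mL to 40 ug/mL, which means an expected step that the limit leaves unreadable from compound 1 to compound 4.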

Compound 4, concentration for half-maximal effect: 6 ug/mL
Compound 4: the middle estimate sits 2.0-fold (0.30 log units) above what was measured, and the stated range covers the measured number.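

Compound 1 gives only a limit in this assay, > 10 ug/mL. Going by these compounds alone, on this aromatic carbon, two ring bonds from the ring oxygen, (2,2,2-trifluoroethoxy)methyl in place of methylcarbamoyl gives a readable number for the first time on the otherwise unchanged core of compound 1, and the change reads as an at least 1.6-fold lower number from compound 1 to compound 4 (0.22 log units; that floor lies within the scatter), so only a floor on the step is known and that floor alone does not establish a real difference. Compound 4 therefore stands apart from the compounds that sit at the limit: the limit of > 10 ug/mL in this assay, at which 2 of the 4 values shown sit.

Going by these compounds, the true size of the step stays open, since compound 1 has no number to measure it from. The compounds shown also leave open which part of the new group goes with the readable number, and how a hydroxymethyl, an aminomethyl, a carboxylic acid or a plain ethoxymethyl group on this carbon would read in this assay.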